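This account rests on a few compounds, and the source may have more. Where it says the series, first, only, none or still open, it means among the compounds named here.

Measured so far in a functional assay on HCT-116 cells (Homo sapiens) for inhibition, read by MTT assay, with a stated time of 72 h; a lower number here means a stronger inhibitor, a higher number a weaker inhibitor:
Compound 1 `COc1cc2c(Oc3ccc(NC(=O)c4nn(-c5ccccc5C(F)(F)F)ccc4=O)cc3)ccnc2cc1OCC(=O)NO`: 9500 nM
Compound 2 `COc1cc2c(Oc3ccc(NC(=O)c4nn(-c5ccc(Cl)c(C(F)(F)F)c5)cc(C)c4=O)cc3)ccnc2cc1OCC(=O)NO`: 350 nM

Compound 2, at 350 nM, holds the lower of the two numbers, and its gap to compound 1 lies beyond the scatter. Compound 3 `COc1cc2c(Oc3ccc(NC(=O)c4nn(-c5ccccc5C)cc(C)c4=O)cc3)ccnc2cc1OCC(=O)NO` carries 2-methylphenyl in place of 4-chloro-3-(trifluoromethyl)phenyl on an aromatic nitrogen. Within the data shown here, no measured pair differs by this change alone, so the size of the step is uncertain. A moderate rise in this assay, beyond the scatter, is expected, since compound 1 at 9500 nM shows that a different group on that nitrogen, alongside other differences, can come with a much higher number. The estimated change is a 5.7-fold higher number from compound 2 to compound 3 (0.76 log units; beyond the scatter). For compound 3 the expected value is 2000 nM, with an estimated range of 600 nM to 7000 nM.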

Compound 3, half-maximal inhibitory concentration: 9260 nM
The estimate for compound 3 lay 4.6-fold (0.67 log units) below the measured number; the whole stated range lies below it.
By their numbers in this assay, from the lowest: compound 2; then compounds 3 and 1 (each within the scatter of the next).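

In this assay, among these compounds, putting 2-methylphenyl in place of 4-chloro-3-(trifluoromethyl)phenyl on the aromatic nitrogen gives a 26-fold higher number from compound 2 to compound 3 (1.42 log units; beyond the scatter), the first comparison in which only this group differs. It shows that this position alone can carry a large change in the number, with the rest of the molecule held the same. Nothing measured here bears on the reason for the step.

Still open, from the compounds shown here alone, is whether the chlorine, the trifluoromethyl or the methyl accounts for most of the step, since all three differ at once. Also open, going by these compounds, is how a phenyl ring carrying an amine or a carboxylic acid would behave at this position.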